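The compounds below may be only part of what the source reports. "The series", "measured", "known", "first", "only" and "open" are said of these compounds alone.

Measured compounds:
Compound 1 `CC(=O)Nc1ccc(S(=O)(=O)Nc2cccc(-c3nc(-c4ccc(NC(=O)c5cccnc5)cc4C(F)(F)F)no3)c2)cc1`: > 10000 nM
Compound 2 `O=C(Nc1cccc(-c2nc(-c3ccc(NC(=O)c4cccnc4)cc3Cl)no2)c1)Nc1ccc(Cl)c(C(F)(F)F)c1`: 1900 nM

In a functional assay on MDA-MB-231 cells (Homo sapiens) for antiproliferative activity, read by MTT assay, with a stated time of 72 h (on this read-out higher numbers stand for weaker inhibition and lower numbers for stronger inhibition), compound 1 gives > 10000 nM, which is a limit of the assay rather than a number. Compound 1 therefore sits at the limit of > 10000 nM in this assay, at which 1 of the 2 values shown sits. In this assay, for the measured compounds named here, compound 2 gives 1900 nM, the only actual number among the two values shown. Going by the values given here, compound 1 and compound 2 differ in more than one place, so their two values show only that one compound gave a number and the other did not.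

Compound 3 `CC(=O)Nc1ccc(NC(=O)Nc2cccc(-c3nc(-c4ccc(NC(=O)c5cccnc5)cc4Cl)no3)c2)cc1Br` is built from compound 2 by one change: 4-acetamido-3-bromophenyl in place of 4-chloro-3-(trifluoromethyl)phenyl on an amide-type nitrogen. Among the compounds with values here, no measured pair differing in a single place is available to calibrate this change, so the expectation rests on compound 2 alone. The step is expected to be a moderate loss of potency, a 2.4-fold higher number from compound 2 to compound 3 (0.37 log units; beyond the scatter), somewhat beyond the usual scatter. Compound 3 is therefore estimated at 4500 nM, with a likely range from 1500 nM to 13000 nM.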

Compound 3, half-maximal inhibitory concentration: 1000 nM
The estimate for compound 3 lay 4.5-fold (0.65 log units) above the measured number; measured number below the stated range.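

In this assay, putting 4-acetamido-3-bromophenyl in place of 4-chloro-3-(trifluoromethyl)phenyl on the amide-type nitrogen gives a 1.9-fold lower number from compound 2 to compound 3 (0.28 log units; within the scatter), so the two compounds cannot be told apart on this read-out. This is the first pair shown that differs in one place, and it shows that this position can carry a group with a hydrogen-bond donor, a hydrogen-bond acceptor and a double bond outside the ring with no change beyond the scatter. No measurement shown bears on what lies behind this result.

For the compounds shown here, compound 1 differs from the others in more than one place, so no step involving it can be read. Going by these compounds, what a group without an aromatic ring, such as a cyclohexyl ring or a longer alkyl chain, would do on this nitrogen stays open.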